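The source may hold more compounds than are shown below. What is called first, only, known or untested is meant among the compounds shown, and "the series" means these compounds.

Working notes on a series sharing the core of compound 1 `Cc1nc(C(=O)Nc2ccc(Cl)c(-c3nnc4c(Cl)cccn34)c2)cs1`, in which the group on the carbonyl carbon is varied. In a functional assay on MDA-MB-468 cells (Homo sapiens) for antiproliferative activity, read by MTT assay, with a stated time of 72 h (on this read-out higher numbers stand for weaker inhibition and lower numbers for stronger inhibition), compound 1, bearing 2-methyl-1,3-thiazol-4-yl, gives only a limit of the assay, > 100000 nM. Among the compounds with values here, compound 2 `O=C(Nc1ccc(Cl)c(-c2nnc3c(Cl)cccn23)c1)c1c(F)cccc1Cl` carries 2-chloro-6-fluorophenyl on the carbonyl carbon and in this assay gives 57600 nM, the only actual number in the set. Compound 3 `O=C(Nc1ccc(Cl)c(-c2nnc3c(Cl)cccn23)c1)c1ccccc1Cl`, with 2-chlorophenyl, gives in this assay a limit, > 100000 nM. Both limits sit at the limit of > 100000 nM in this assay, at which 2 of the 3 values shown sit. The measured steps are accordingly small or unreadable: an at least 1.7-fold lower number from compound 1 to compound 2 (0.23 log units; that floor lies within the scatter), an at least 1.7-fold higher number from compound 2 to compound 3 (0.23 log units; that floor lies within the scatter), and a step that the two limits leave unreadable from compound 1 to compound 3.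

The next compound, compound 4 `O=C(Nc1ccc(Cl)c(-c2nnc3c(Cl)cccn23)c1)c1ccccn1`, differs from compound 2 by pyridin-2-yl in place of 2-chloro-6-fluorophenyl on a carbonyl carbon. Within the data shown here, two steps bear on this. The earlier exchange of 2-methyl-1,3-thiazol-4-yl for 2-chloro-6-fluorophenyl gave an at least 1.7-fold lower number from compound 1 to compound 2 (0.23 log units; that floor lies within the scatter), and removal of the fluoro gave an at least 1.7-fold higher number from compound 2 to compound 3 (0.23 log units; that floor lies within the scatter). Compound 4 both returns to a six-membered aromatic ring with one hetero atom and drops both halogens, so a move back toward the limit, meaning weaker inhibition in this assay, is expected. Compound 4 is therefore expected to give 150000 nM in this assay, between 50000 nM and 500000 nM, an estimated step of a 2.6-fold higher number from compound 2 to compound 4 (0.42 log units; beyond the scatter).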

Compound 4, half-maximal inhibitory concentration: > 100000 nM
Compound 4 ended at the assay's limit (the forecaster's own chance of this, stated with the estimate: 65%); the middle value does not contradict the limit.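

In this assay, within the data shown here, the exchange of 2-chloro-6-fluorophenyl for pyridin-2-yl on the carbonyl carbon gives an at least 1.7-fold higher number from compound 2 to compound 4 (0.23 log units; that floor lies within the scatter), so this change shows no step that can be told from the scatter. Among these compounds, compound 4 is the first in the set with pyridin-2-yl, a group with a hydrogen-bond acceptor and no halogen, and its value is a limit of the assay; the steps from compound 1 and from compound 3 to compound 4 cannot be read, as both ends of each are limits. Among the groups on the carbonyl carbon, only 2-chloro-6-fluorophenyl gives an actual number, and no order can be set among the other three: the limit of > 100000 nM in this assay, at which 3 of the 4 values shown sit.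

The compounds shown leave open whether a group of another kind on the carbonyl carbon, such as an open alkyl chain, an amine or a phenyl ring bearing a carboxylic acid, would give a number clearly lower than that of compound 2. They also leave open how far compound 1, compound 3 and compound 4 lie from one another in this assay.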